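Permeability notes on a shared-core series, toward compound 4

The source may report more compounds than this note shows. Statements on the series, on what has been measured and on what is new or still open speak of the compounds shown alone.

Measured in an ADME assay for permeability, using PAMPA, with a stated time of 30 min, at pH 7.4 (on this read-out lower numbers stand for lower permeability and higher numbers for higher permeability), so far:
compound 1 `COc1ccc(F)cc1CNCCCNc1ccnc2cc(Cc3ccc(C#N)cc3)ccc12`: 23 10^-6 cm/s
compound 2 `COc1ccc(-c2ccc3c(NCCCNCc4cccc(OC)c4O)ccnc3c2)cc1`: 237 10^-6 cm/s
compound 3 `FC(F)(F)c1ccc(-c2ccc3c(NCCCNCc4ccco4)ccnc3c2)cc1`: 237 10^-6 cm/s

Compound 2 stands level with compound 3 at the digits given, and together they hold the highest of the three numbers in this assay. Compound 1, which carries a different attachment on the shared core and a different substituted benzyl group on the chain, lies far below both, a gap well beyond the scatter. Between compound 2 and compound 3 nothing beyond the scatter separates the two values, although the group on the pendant phenyl ring differs (methoxy against trifluoromethyl).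

Compound 4 `COc1cccc(CNCCCNc2ccnc3cc(-c4ccc(F)cc4)ccc23)c1O` differs from compound 2 in one place: fluoro in place of methoxy on an aromatic carbon. Going by the values given here, no pair of measured compounds covers exactly this change, so its size must be judged from what is at hand. Because compound 3 gives 237 10^-6 cm/s with a quite different group at that same ring, the step from compound 2 to compound 4 is expected to be a 1.0-fold higher number from compound 2 to compound 4 (0.01 log units; within the scatter), that is, nothing beyond the scatter in this assay. Compound 4 is therefore expected at 240 10^-6 cm/s, with a range from 120 10^-6 cm/s to 420 10^-6 cm/s.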

Compound 4, apparent permeability: 237 10^-6 cm/s
Compound 4: middle estimate off by 1.0-fold (0.01 log units), on the high side, within the range that was stated.
By their numbers in this assay, from the lowest: compound 1; then compounds 2, 3 and 4 (each within the scatter of the next).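

In this assay, going by these compounds alone, the change to fluoro in place of methoxy on an aromatic carbon, para to a large group, gives no change at the digits printed from compound 2 to compound 4 (within the scatter), and this is the first reading of a change made in one place only. At this position, then, going from 4-methoxyphenyl to 4-fluorophenyl exchanges a group of 2 heavy atoms and 1 hydrogen-bond acceptor for a group of 1 heavy atom and 0 hydrogen-bond acceptors, with no shift in the read-out beyond the scatter. No measurement at hand explains why the read-out holds steady across this change.

Within the data shown here, still open is whether the same position stays level with a primary amine, a carboxylic acid or a longer alkyl chain in place of fluoro or methoxy, as this single step covers only two small neutral groups. Also open, from the compounds shown here alone, is which part of compound 1 goes with its value of 23 10^-6 cm/s, as it differs from the other compounds in more than one place and its steps to them cannot be read.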